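Sulfonyl substituent and solubility in the shared core

The source may report more compounds than this note shows. Statements on the series, on what has been measured and on what is new or still open speak of the compounds shown alone.

Measured compounds:
compound 1 `O=C(NCc1ccc(S(=O)(=O)c2cccc(C(F)(F)F)c2)cc1)N1Cc2ccncc2C1`: 10000 nM
compound 2 `CCCn1cc(S(=O)(=O)c2ccc(CNC(=O)N3Cc4ccncc4C3)cc2)cn1`: 105000 nM
compound 3 `O=C(NCc1ccc(S(=O)(=O)C2CCC(F)(F)CC2)cc1)N1Cc2ccncc2C1`: 35000 nM

In a physicochemical assay for solubility, in phosphate buffer, with a stated time of 24 h, at pH 7.4, tested at 100 uM (a higher number here means a more soluble compound, a lower number a less soluble compound), compound 2 stands highest of the three numbers. The nearest number is separated by a 3.0-fold lower number from compound 2 to compound 3 (0.48 log units; beyond the scatter), the furthest by an 11-fold higher number from compound 1 to compound 2 (1.02 log units; beyond the scatter). Every step so far changes only the group on the sulfonyl sulfur, and all lie beyond the scatter: a 3.5-fold higher number from compound 1 to compound 3 (0.54 log units; beyond the scatter) is modest, the other two are given above.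

Compound 4 `O=C(NCc1ccc(S(=O)(=O)N2CCOCC2)cc1)N1Cc2ccncc2C1` is the next member. Its change from compound 2 is morpholin-4-yl in place of 1-propyl-1H-pyrazol-4-yl on a sulfonyl sulfur. For the measured compounds named here, no measured step exchanges an aromatic ring on the sulfonyl sulfur for a nitrogen-linked saturated ring, so the closest guide is the modest lowering seen when the non-aromatic 4,4-difluorocyclohexyl replaced the aromatic 1-propyl-1H-pyrazol-4-yl, a 3.0-fold lower number from compound 2 to compound 3 (0.48 log units; beyond the scatter). Compound 2 already sits near the tested concentration, which leaves little room upward. The expectation for compound 4 is therefore a step of a 1.5-fold lower number from compound 2 to compound 4 (0.18 log units; within the scatter), a modest lowering or none beyond the scatter. Compound 4 is estimated at 70000 nM in this assay, with a range from 30000 nM to 150000 nM.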

Compound 4, solubility: 59000 nM
The estimate for compound 4 lay 1.2-fold (0.07 log units) above the measured number; the range from low to high includes it.
By their numbers in this assay, from the lowest: compound 1; then compounds 3, 4 and 2 (each within the scatter of the next, the first and the last beyond it).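

In this assay, morpholin-4-yl shows that a nitrogen-linked saturated ring on a sulfonyl sulfur can stay level with the aromatic 1-propyl-1H-pyrazol-4-yl (a 1.8-fold lower number from compound 2 to compound 4 (0.25 log units; within the scatter)), so among these two groups, having an aromatic ring at this position does not separate the numbers. Morpholin-4-yl also stays within the scatter of 4,4-difluorocyclohexyl (a 1.7-fold higher number from compound 3 to compound 4 (0.23 log units; within the scatter)), which places compound 4 within the scatter of two compounds that remain separated from each other, while compound 1 with 3-(trifluoromethyl)phenyl stands clearly apart from it (a 5.9-fold higher number from compound 1 to compound 4 (0.77 log units; beyond the scatter)). No measurement on hand speaks to what lies behind these numbers.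

The compounds shown leave open whether a piperazin-1-yl ring, an open-chain dimethylamino group or a carboxylic acid on the ring attached to the sulfonyl sulfur would keep the number at the level of compounds 2 and 4 or move it towards compound 1. They also leave open whether the level seen with morpholin-4-yl holds once the urea linker or another part of the shared core is changed.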